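A few compounds are considered here, and "the series" means these few. Any claim that something is new, unique, unknown or untested is made for them only; others in the source may bear on it.

Working notes on the series

The shared core of compound 1 `Cc1ccnc2c1ccn2-c1ccc(C(C)C)cc1Br` carries the isopropyl-bromophenyl arm that is common to every member here. In an assay on isolated protein for binding affinity to corticotropin-releasing factor receptor 1 (Rattus norvegicus) (a lower number here means a stronger inhibitor, a higher number a weaker inhibitor), compound 1 returns only a limit, > 10000 nM, so its position on the scale is not fixed by a number. Compound 2 `Cc1cc(O)nc2c1c(C#N)cn2-c1ccc(C(C)C)cc1Br` adds a hydroxyl and a nitrile to the same core. In this assay compound 2 likewise returns only a limit, > 10000 nM. Among the compounds with values here, both values sit at the same limit, as summed up in the limit of > 10000 nM in this assay, at which 2 of the 2 values shown sit, so no step between measured compounds can be drawn; the two results show only that neither compound reaches measurable binding, and they give no direction for the series.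

Compound 3 `Cc1cc(Cl)nc2c1ccn2-c1ccc(C(C)C)cc1Br` is the next member awaiting measurement. It differs from compound 1 by chloro in place of hydrogen on an aromatic carbon. With both measured compounds at the limit, the expected step of an at least 2.5-fold lower number from compound 1 to compound 3 (0.39 log units; beyond the scatter) can only be guessed: a gain into the measurable range is plausible, but a third limit is about as likely. The estimate for compound 3 in this assay is 4000 nM, within 500 nM to 30000 nM.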

Compound 3, inhibition constant: 79 nM
Compound 3: the middle estimate sits 51-fold (1.70 log units) above what was measured; measured number outside the range, below it.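

Chloro in place of hydrogen on this aromatic carbon, next to the ring nitrogen, is the first single change in the series to yield a measured value in this assay, with an at least 120-fold lower number from compound 1 to compound 3 (2.10 log units; beyond the scatter) as its step. The position therefore responds strongly to substitution, and one chlorine atom, which adds no hydrogen-bond donor or acceptor, is enough to turn a compound held at the limit into one with a measured value. As far as these compounds go, the true size of the step remains unknown, and the printed size is only a bound because compound 1 has a limit and not a number: the limit of > 10000 nM in this assay, at which 2 of the 3 values shown sit.

From the compounds shown here alone, whether the gain is specific to chloro remains open, as the series shows no fluoro, bromo, methoxy or amine on the same carbon. The compounds shown also leave open how far the isopropyl-bromophenyl arm contributes to the value of compound 3, as every member carries this arm and none replaces the bromine or the isopropyl with another group, such as a methyl or a longer chain.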